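Aryl swap on the saturated ring carbon of compound 3

A few compounds are considered here, and "the series" means these few. Any claim that something is new, unique, unknown or untested is made for them only; others in the source may bear on it.

Measured compounds:
compound 1 `COc1cc(C2=NN(C(C)=O)C(c3c(Cl)cccc3Cl)O2)cc(OC)c1OC` 15.9%
compound 2 `COc1cc(C2=NN(C(C)=O)C(c3cc(Cl)cc(Cl)c3)O2)cc(OC)c1OC` 6.6%
compound 3 `COc1ccc(OC)c(C2OC(c3cc(OC)c(OC)c(OC)c3)=NN2C(C)=O)c1` 18.2%

In a functional assay on BGC-823 cells (Homo sapiens) for antiproliferative activity, read by MTT assay, tested at 5 uM (on this read-out higher numbers stand for a stronger effect at the one concentration tested and lower numbers for a weaker effect), compound 3 gives the highest of the three numbers; its gap to compound 1 is within the scatter, while the step of a number 11.6 percentage points higher from compound 2 to compound 3 (beyond the scatter) lies beyond it. Compound 4 `COc1cc(C2=NN(C(C)=O)C(c3ccccc3C(F)(F)F)O2)cc(OC)c1OC` differs from compound 3 by 2-(trifluoromethyl)phenyl in place of 2,5-dimethoxyphenyl on a saturated ring carbon. Going by the values given here, two steps bear on this position: a number 11.6 percentage points higher from compound 2 to compound 3 (beyond the scatter) was modest, and a number 2.3 percentage points higher from compound 1 to compound 3 (within the scatter) was within the scatter, so different aryl groups here have moved the read-out only slightly. Compound 4 is therefore expected to fall in the same band, with a number 5.2 percentage points lower from compound 3 to compound 4 (within the scatter) estimated as a small downward step within the scatter. The estimate for compound 4 in this assay is 13%, ranging from 4% to 22%.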

Compound 4, a percentage reported as inhibition, at one concentration (the size of the read-out at that concentration, not a potency): 34.8%
Estimate against measurement, compound 4: 21.8 percentage points below; the whole stated range lies below it.
By their numbers in this assay, from the lowest: compounds 2, 1 and 3 (each within the scatter of the next, the first and the last beyond it); then compound 4.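

In this assay the 2-(trifluoromethyl)phenyl group stands apart from every earlier aryl group on the saturated ring carbon, with a number 16.6 percentage points higher from compound 3 to compound 4 (beyond the scatter) and a number 28.2 percentage points higher from compound 2 to compound 4 (beyond the scatter) and a number 18.9 percentage points higher from compound 1 to compound 4 (beyond the scatter) as its three steps. The aryl group at this position can therefore shift the read-out further than the earlier largest step, a number 11.6 percentage points higher from compound 2 to compound 3 (beyond the scatter) among the first three compounds, had shown. No available evidence accounts for this gain.

On these data alone, it remains open whether the gain belongs to the trifluoromethyl group itself or to its place on the phenyl ring. Also open, as far as these compounds go, is what a phenyl ring carrying a nitrile, an amine or a carboxylic acid would give at this carbon.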